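This account rests on a few compounds, and the source may have more. Where it says the series, first, only, none or still open, it means among the compounds named here.

Series values in a functional assay on DU-145 cells (Homo sapiens) for inhibition, read by trypan blue exclusion, with a stated time of 96 h; a lower number here means a stronger inhibitor of growth, a higher number a weaker inhibitor of growth:

- compound 1 `CCOc1ccc(/C=C(\C(=O)c2ccc(Cl)cc2)S(=O)(=O)Cc2ccc(F)cc2)cc1OC`: 50000 nM
- compound 2 `Cc1ccc(C)c(/C=C(\C(=O)c2ccc(Cl)cc2)S(=O)(=O)c2ccc(Br)cc2)c1`: 1000 nM
- compound 3 `COc1cc(OC)c(/C=C(/SCc2ccc(Cl)cc2)C(=O)c2ccc([N+](=O)[O-])cc2)c(OC)c1`: > 100000 nM (a limit of the assay, not a number)

Of the two actual numbers, compound 2 has the lower, and compound 1 is the nearest, with a gap well beyond the usual scatter. These two compounds differ in more than one place, so their values show only that gap and do not isolate any single change.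

The next compound to be tested is compound 4 `COc1ccc(/C=C(\C(=O)c2ccc(Cl)cc2)S(=O)(=O)c2ccc(Br)cc2)cc1`. Relative to compound 2, it has 4-methoxyphenyl in place of 2,5-dimethylphenyl on a double-bonded chain carbon bound to a double-bonded chain carbon. The sulfonyl side and the chlorophenyl ketone stay the same.

Within the data shown here, no measured pair covers this replacement, so the basis for an expectation is thin. Among the measured compounds shown here, the one hint is compound 1, at 50000 nM, which also carries oxygen-linked groups on the aryl ring at this place, although it differs elsewhere too. In this assay, a moderate step toward a higher number is therefore expected, slightly beyond the scatter. The expected change is a 3.0-fold higher number from compound 2 to compound 4 (0.48 log units; beyond the scatter). For compound 4 the estimated value is 3000 nM, with an expected range of 500 nM to 20000 nM.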

Compound 4, concentration for 50% growth inhibition: 10000 nM
For compound 4 the middle estimate is 3.3-fold (0.52 log units) below the measured one; low and high end bracket the measured number.
By their numbers in this assay, from the lowest: compound 2; then compound 4; then compound 1. At a limit, above all of these: compound 3.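

In this assay, among these compounds, replacing 2,5-dimethylphenyl with 4-methoxyphenyl on a double-bonded chain carbon bound to a double-bonded chain carbon gives a 10-fold higher number from compound 2 to compound 4 (1.00 log units; beyond the scatter), the first comparison that isolates a single change. The value at this position therefore depends on the aryl group it carries: with the sulfonyl side and the chlorophenyl ketone held constant, this replacement alone moves the number beyond the scatter. The heavy-atom count stays at 8 and a hydrogen-bond acceptor enters, but this one pair cannot separate the loss of the methyl groups from the gain of the methoxy group or from the changed substitution on the ring, and no measurement shown here accounts for the step.

As far as these compounds go, compound 3 gives > 100000 nM as a limit of the assay and not a number, so its distance from the other compounds stays open. Also open, from the compounds shown here alone, is how this position responds to other groups, such as an amine or a carboxylic acid on the aryl ring, and whether the step persists when the sulfonyl side or the ketone changes.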